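Chain-length extension on the aryl urea: compound 3 to compound 4

This account rests on a few compounds, and the source may have more. Where it says the series, first, only, none or still open, it means among the compounds named here.

Compound 3 `CCCCCCCCc1ccc(NC(=O)Nc2c(C(C)C)cccc2C(C)C)cc1` gives 11 nM in an assay on isolated protein for inhibition of acyl-CoA:cholesterol acyltransferase (Oryctolagus cuniculus); a lower number here means a stronger inhibitor, a higher number a weaker inhibitor. Among the three measured compounds it stands second highest, and its nearest neighbour, compound 1 `CCCCCCCCCc1ccc(NC(=O)Nc2c(C(C)C)cccc2C(C)C)cc1` at 9 nM, lies a 1.2-fold higher number from compound 1 to compound 3 (0.09 log units; within the scatter) away, while compound 2 `CCCCCCCCCCCCc1ccc(NC(=O)Nc2c(C(C)C)cccc2C(C)C)cc1` at 15 nM lies a 1.4-fold lower number from compound 2 to compound 3 (0.13 log units; within the scatter) away. Compound 4 `CCCCCCCCCCCc1ccc(NC(=O)Nc2c(C(C)C)cccc2C(C)C)cc1` differs from compound 3 by propyl in place of hydrogen on a saturated chain carbon, eight bonds along the chain from an aromatic carbon. Within the data shown here, two measured steps bear on this: a 1.7-fold higher number from compound 1 to compound 2 (0.22 log units; within the scatter) and a 1.4-fold lower number from compound 2 to compound 3 (0.13 log units; within the scatter), both within the scatter, and so is a 1.2-fold higher number from compound 1 to compound 3 (0.09 log units; within the scatter). Longer or shorter chains on this carbon have therefore shown no step beyond the scatter, and none is expected here. Compound 4 is expected to give 12 nM, with a range of 6 nM to 25 nM, which means an expected step of a 1.1-fold higher number from compound 3 to compound 4 (0.04 log units; within the scatter).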

Compound 4, half-maximal inhibitory concentration: 9 nM
Compound 4: the middle estimate sits 1.3-fold (0.12 log units) above what was measured; the range from low to high includes it.
By their numbers in this assay, from the lowest: compounds 1, 4, 3 and 2 (each within the scatter of the next).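

Every new step on this saturated chain stays within the scatter in this assay: propyl for hydrogen (a 1.2-fold lower number from compound 3 to compound 4 (0.09 log units; within the scatter)), hydrogen for methyl (a 1.7-fold lower number from compound 2 to compound 4 (0.22 log units; within the scatter)) and ethyl for hydrogen (no change at the digits printed from compound 1 to compound 4 (within the scatter)). Propyl for hydrogen now reads alike on two chain lengths: the same change on two cores in this assay, a 1.7-fold higher number (0.22 log units; within the scatter) from compound 1 to compound 2 and a 1.2-fold lower number (0.09 log units; within the scatter) from compound 3 to compound 4, 2.0-fold (0.31 log units) apart, within the scatter of two such steps. Hydrogen for methyl does the same: the same change on two cores in this assay, a 1.2-fold higher number (0.09 log units; within the scatter) from compound 1 to compound 3 and a 1.7-fold lower number (0.22 log units; within the scatter) from compound 2 to compound 4, 2.0-fold (0.31 log units) apart, within the scatter of two such steps. The compounds shown leave open whether this holds for a much longer chain, or for a chain ending in a carboxylic acid or an amine.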